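A few compounds are considered here, and "the series" means these few. Any claim that something is new, unique, unknown or untested is made for them only; others in the source may bear on it.

Compound 1 `CCCCCOc1ccc2oc(/C=C/[S+](C)[O-])cc(=O)c2c1` gives 1600 nM in a functional assay on A549 cells (Homo sapiens) for cytotoxicity, with a stated time of 48 h; on this read-out higher numbers stand for weaker inhibition and lower numbers for stronger inhibition.
Compound 2 `Cc1ccc2oc(/C=C/[S+](C)[O-])cc(=O)c2c1` gives 1700 nM.
Compound 3 `CC(C)CCOc1ccc2oc(/C=C/[S+](C)[O-])cc(=O)c2c1` gives 1000 nM.

Among these three numbers compound 1 stands second highest; the nearest is the step of a 1.1-fold higher number from compound 1 to compound 2 (0.03 log units; within the scatter), the furthest the step of a 1.6-fold lower number from compound 1 to compound 3 (0.20 log units; within the scatter). Compound 4 `C[S+]([O-])/C=C/c1cc(=O)c2cc(C#N)ccc2o1` has not been measured. It differs from compound 1 in one place: cyano in place of pentyloxy on an aromatic carbon. Two measured steps also exchange the group on that aromatic carbon, a 1.1-fold higher number from compound 1 to compound 2 (0.03 log units; within the scatter) and a 1.7-fold lower number from compound 2 to compound 3 (0.23 log units; within the scatter), and both stay within the scatter. Among the compounds with values here, no measured compound carries cyano, so the step from compound 1 to compound 4 is expected to stay small as well: a 1.1-fold lower number from compound 1 to compound 4 (0.03 log units; within the scatter). Compound 4 is therefore estimated at 1500 nM, with a range from 600 nM to 4000 nM.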

Compound 4, half-maximal inhibitory concentration: > 10000 nM
Compound 4: only a limit was reported; the forecaster's own chance of this, stated with the estimate: 5%; at least 6.6-fold (0.82 log units) between middle value and limit.
By their numbers in this assay, from the lowest: compounds 3, 1 and 2 (each within the scatter of the next). At a limit, above all of these: compound 4.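

Methyl, pentyloxy and isopentyloxy on this aromatic carbon gave values within the scatter of one another, so the position looked indifferent to its group, but cyano breaks that picture: an at least 6.2-fold higher number from compound 1 to compound 4 (0.79 log units; beyond the scatter), an at least 10-fold higher number from compound 3 to compound 4 (1.00 log units; beyond the scatter) and an at least 5.8-fold higher number from compound 2 to compound 4 (0.76 log units; beyond the scatter). The group here can therefore matter a great deal, with weaker inhibition for compound 4 than for any of the others. The result for compound 4 is a limit, not a number: the limit of > 10000 nM in this assay, at which 1 of the 4 values shown sits.

Going by these compounds, how far compound 4 lies past that limit remains open. Also open, on these data alone, is how an amine, a carboxylic acid or an amide on the same carbon would behave, and so whether cyano alone stands apart.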